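A few compounds are considered here, and "the series" means these few. Any claim that something is new, unique, unknown or untested is made for them only; others in the source may bear on it.

Among the compounds with values here, in an ADME assay on MT2 cells (Homo sapiens) for cytotoxicity, read by XTT assay, with a stated time of 4 days (a lower number here means that less compound is tolerated, a higher number that more compound is tolerated), two compounds have numbers so far. Compound 1 `Cc1nc(C(NC(=O)C(=O)Nc2ccc(Cl)cc2)C2CCCCN2C)sc1CCO` gives 88000 nM, and compound 2 `Cc1nc(C(NC(=O)C(=O)Nc2ccc(F)cc2)C2CCCCN2)sc1CCO` gives 109000 nM. These two values lie within the scatter of each other, so compound 2 stands level with compound 1 on the numbers shown. Compound 3 `Cc1nc(C(NC(=O)C(=O)Nc2ccc(Cl)cc2)C2CCCCN2)sc1CCO` departs from compound 2 in one place: chloro in place of fluoro on an aromatic carbon, with chloro in place of fluoro on an aromatic carbon, para to a large group. Within the data shown here, no measured pair of compounds differs in one place only, so the data offer no direct guide to the size of this change. Nothing beyond the scatter is expected in this assay, in either direction. The expected step, a 1.1-fold lower number from compound 2 to compound 3 (0.06 log units; within the scatter), is correspondingly small. For compound 3 the estimate is 95000 nM, with an expected range of 50000 nM to 170000 nM.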

Compound 3, half-maximal cytotoxic concentration: > 62000 nM
Compound 3 ended at the assay's limit; the forecaster's own chance of this, stated with the estimate: 15%; the middle value lies beyond the limit too.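

In this assay compound 3 gives > 62000 nM, which is a limit of the assay and not a number. Within the data shown here, no step from compound 1 or compound 2 to compound 3 can be read from it. The compounds shown leave open whether chloro in place of fluoro, or hydrogen in place of methyl on the ring amine nitrogen, changes the number at all.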